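Catechol in Place of a Dichlorophenol on the Hydrazone

The compounds below may be only part of what the source reports. "The series", "measured", "known", "first", "only" and "open" are said of these compounds alone.

Compound 2 `O=C(CSc1nnc(-c2ccncc2)o1)N/N=C/c1cc(Cl)cc(Cl)c1O` stands lowest of the two numbers in a functional assay on HepG2 cells (Homo sapiens) for cytotoxicity, read by MTT assay, with a stated time of 48 h (on this read-out lower numbers stand for stronger inhibition and higher numbers for weaker inhibition), at 3260 nM. Among the compounds with values here, its nearest neighbour is compound 1 `O=C(CSc1nnc(-c2ccncc2)o1)N/N=C/c1ccc(Br)cc1`, which in this assay gives 18600 nM; the only measured step, a 5.7-fold lower number from compound 1 to compound 2 (0.76 log units; beyond the scatter), bears on the change ahead. Compound 3 `O=C(CSc1nnc(-c2ccncc2)o1)N/N=C/c1ccc(O)c(O)c1` differs from compound 2 by 3,4-dihydroxyphenyl in place of 3,5-dichloro-2-hydroxyphenyl on a carbon with a double bond to nitrogen. That earlier step, made at the same carbon, was modest and beyond the scatter, so a step of comparable size toward a higher number is expected for compound 3, namely a 2.5-fold higher number from compound 2 to compound 3 (0.39 log units; beyond the scatter). Compound 3 is therefore estimated at 8000 nM, within a range from 2500 nM to 25000 nM.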

Compound 3, half-maximal inhibitory concentration: 760 nM
Compound 3: the middle estimate sits 11-fold (1.02 log units) above what was measured; the whole stated range lies above it.
By their numbers in this assay, from the lowest: compound 3; then compound 2; then compound 1.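

In this assay, within the data shown here, the halogens of the earlier compounds prove unnecessary at this carbon: with no chlorine or bromine on the ring, 3,4-dihydroxyphenyl gives a 4.3-fold lower number from compound 2 to compound 3 (0.63 log units; beyond the scatter) and, against 4-bromophenyl, a 24-fold lower number from compound 1 to compound 3 (1.39 log units; beyond the scatter). Compound 3 therefore stands lowest of the three, with both steps beyond the scatter. No evidence here accounts for this order. Going by these compounds, it remains open whether both hydroxyl groups are needed, and whether methoxy groups or an amine on the phenyl ring would serve as well.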